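The source may hold more compounds than are shown below. What is called first, only, known or untested is meant among the compounds shown, and "the series" means these compounds.

Measured compounds:
compound 1, `CCCC[C@H](NC(=O)[C@H](CCCCN)NC(=O)[C@H](CCCNC(=N)N)NC(=O)c1ccc(/C=C2\SC(=S)N(C3CCCC3)C2=O)cc1)C(N)=O`: 2.31 10^-6 cm/s
compound 2, `CCCC[C@H](NC(=O)[C@H](CCCCN)NC(=O)[C@H](CCCNC(=N)N)NC(=O)c1ccc(/C=C2\SC(=O)N(CCOC(C)=O)C2=O)cc1)C(N)=O`: "impermeable" (no number reported)

Among the compounds with values here, in an ADME assay for permeability, using PAMPA (on this read-out lower numbers stand for lower permeability and higher numbers for higher permeability), compound 1 gives 2.31 10^-6 cm/s, the only number reported. Compound 2 is reported in this assay only as "impermeable" (no number reported), without a number, and the two compounds differ in more than one place, so nothing beyond their two entries can be said of them together. Compound 3, `CCCC[C@H](NC(=O)[C@H](CCCCN)NC(=O)[C@H](CCCNC(=N)N)NC(=O)c1ccc(/C=C2\SC(=S)N(C3CCCCC3)C2=O)cc1)C(N)=O`, has not been measured. It differs from compound 1 by cyclohexyl in place of cyclopentyl on an amide-type nitrogen in a ring. Within the data shown here, no measured step guides this change, and any shift in this assay is expected to stay within the usual scatter or at most slightly above it. The estimated step is a 1.2-fold higher number from compound 1 to compound 3 (0.08 log units; within the scatter), giving for compound 3 an expected value of 2.8 10^-6 cm/s with a range from 1.2 10^-6 cm/s to 6 10^-6 cm/s.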

Compound 3, apparent permeability: 1.82 10^-6 cm/s
The estimate for compound 3 lay 1.5-fold (0.19 log units) above the measured number, within the range that was stated.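

In this assay, within the data shown here, the one measured step at this position, cyclohexyl in place of cyclopentyl on an amide-type nitrogen in a ring, is a 1.3-fold lower number from compound 1 to compound 3 (0.10 log units; within the scatter). Across this one change in ring size, compound 1 and compound 3 cannot be told apart on this read-out. No available evidence accounts for this result. Going by these compounds, whether an amine, a carboxylic acid or a longer chain on this nitrogen would give a step beyond the scatter remains open. Compound 2 differs from compound 1 in more than one place and offers no comparison.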